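The source may report more compounds than this note shows. Statements on the series, on what has been measured and on what is new or still open speak of the compounds shown alone.

Measured so far in a functional assay on the whole organism with Rattus norvegicus as the target; a higher number here means that more compound is needed for the effect, a lower number that less compound is needed:

Compound 1 `CCOC(=O)C(=O)Nc1nc(-c2ccc3c(c2)OCCO3)cs1` — compound 1 gives > 10 mg/kg, which is a limit of the assay and not a number.
Compound 2 `NC(=O)C(=O)Nc1nc(-c2ccc3c(c2)OCCO3)cs1` — compound 2 gives > 30 mg/kg, again a limit and not a number.
Compound 3 `CCOC(=O)C(=O)Nc1nc(-c2ccc3c(c2)CCCC3)cs1` — compound 3 gives > 10 mg/kg, a limit as well.

The change from compound 1 to compound 2 is amino in place of ethoxy on a carbonyl carbon. The step that the two limits leave unreadable from compound 1 to compound 2 cannot be read, since both ends are limits: compounds 1 and 3 sit at the limit of > 10 mg/kg in this assay, at which 2 of the 3 values shown sit, and compound 2 sits at the limit of > 30 mg/kg in this assay, at which 1 of the 3 values shown sits.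

Compound 4 `NC(=O)C(=O)Nc1nc(-c2ccc3c(c2)CCCC3)cs1` is reached from compound 3 by the same change, (amino in place of ethoxy on a carbonyl carbon). The difference between the core of compound 1 and the core of compound 3 is not broken down here.

For the measured compounds named here, no measured step in this assay gives a size for this change, so the step that the limit leaves unreadable from compound 3 to compound 4 is only an estimate. Compound 4 is expected near 30 mg/kg, most likely again reported as a limit, with a range from 10 mg/kg to 100 mg/kg.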

Compound 4, dose for half-maximal effect: > 10 mg/kg
Compound 4 was reported as a limit; the forecaster's own chance of this, stated with the estimate: 80%; the middle value is on the limit's open side.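

Compound 4 gives > 10 mg/kg, a limit and not a number. No step can be read from compound 3 to compound 4, or from compound 1 to compound 2. The compounds shown leave open how large the change from ethoxy to amino is on either core.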